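The compounds below may be only part of what the source reports. "The series", "measured", "known", "first", "only" and "open" are said of these compounds alone.

Compound 2 `O=C(CCC1CCN(CC2CCCCC2)CC1)c1ccc2[nH]ccc2c1` gives 100% in an assay for displacement of a labelled ligand from 5-hydroxytryptamine receptor 4 (Homo sapiens), with a stated time of 60 min, tested at 1 uM; on this read-out higher numbers stand for more inhibition at the one concentration tested (going by the name of the read-out) and lower numbers for less inhibition. It stands level with compound 1 `COc1c(C(=O)CCC2CCN(CC3CCCCC3)CC2)cc(Cl)c2[nH]ccc12`, which in this assay gives 100%, and the two together are the highest of the three numbers. Furthest from it is compound 3 `CCCCN1CCC(CCC(=O)c2ccc3[nH]ccc3c2)CC1`, which in this assay gives 97%; the step of a number 3 percentage points lower from compound 2 to compound 3 (within the scatter) lies within the scatter. Compound 4 `COc1c(C(=O)CCC2CCN(CC3CCCCC3)CC2)ccc2[nH]ccc12` differs from compound 2 by methoxy in place of hydrogen on an aromatic carbon. Going by the values given here, no measured step touches that ring: the single-point step a number 3 percentage points lower from compound 2 to compound 3 (within the scatter) alters a chain on the ring amine, and compound 1 carries two added groups at once, so it shows only that a methoxy-bearing core reaches the same top value. Compound 4 is therefore expected to move by no more than the scatter, a step of a number 3 percentage points lower from compound 2 to compound 4 (within the scatter), giving an estimated 97% with a range from 88% to 100%.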

Compound 4, a percentage reported as inhibition, at one concentration (the size of the read-out at that concentration, not a potency): 100%
The estimate for compound 4 lay 3 percentage points below the measured number; the range from low to high includes it.
By their numbers in this assay, from the lowest: compounds 3, 1, 2 and 4 (each within the scatter of the next).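

In this assay methoxy alone on this aromatic carbon, ortho to a fused ring, gives no change at the digits printed from compound 2 to compound 4 (within the scatter) and so leaves the number level, which compound 1 with its two added groups could not show. Chloro on the same core, read through hydrogen in its place, gives no change at the digits printed from compound 1 to compound 4 (within the scatter) and likewise shows no separate effect at this single concentration. Nothing measured here explains these level numbers.

Whether an ethoxy group, a hydroxyl or an amine on this carbon would hold the number stays open, and a single-concentration percentage leaves any difference in potency among these compounds unresolved.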